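This account rests on a few compounds, and the source may have more. Where it says the series, first, only, none or still open, it means among the compounds named here.

Measured so far in a functional assay on MDA-MB-231 cells (Homo sapiens) for inhibition, read by MTT assay, with a stated time of 48 h (on this read-out higher numbers stand for weaker inhibition and lower numbers for stronger inhibition), with both values being limits:
- Compound 1 `Cn1c(/C=C2\SC(=O)N(CC(=O)N3CCCCC3)C2=O)nc2ccccc21` gives > 50000 nM as a limit
- Compound 2 `CC(C)n1c(/C=C2\SC(=O)N(CC(=O)N3CCCC3)C2=O)nc2ccccc21` gives > 50000 nM as a limit

Compound 2 has only > 50000 nM to its name, which is a limit and not a number. Among the measured compounds shown here, the whole record so far reads (the limit of > 50000 nM in this assay, at which 2 of the 2 values shown sit), so neither measured compound can be placed above or below the other, and no measured step is available to size the next change.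

Compound 3 `CC(C)n1c(/C=C2\SC(=O)N(CC(=O)N3CCCCC3)C2=O)nc2ccccc21` differs from compound 2 at one place, with piperidin-1-yl in place of pyrrolidin-1-yl on a carbonyl carbon. In this assay no step beyond the scatter is expected, in either direction, given that the record so far stands at the limit of > 50000 nM in this assay, at which 2 of the 2 values shown sit, and offers no sign of measurable inhibition. The most likely outcome is that compound 3 will also be reported only as a limit. The expected step is a number no higher from compound 2 to compound 3 (the limit leaves the size open), an estimate read against a limit and not against a number. For compound 3 the estimated value is 50000 nM, with an expected range from 25000 nM to 100000 nM in this read-out.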

Compound 3, half-maximal inhibitory concentration: > 50000 nM
Compound 3: only a limit was reported; the forecaster's own chance of this, stated with the estimate: 85%; the middle value sits exactly at the limit.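

Compound 3 is also reported only as a limit, so the steps to it from compound 2 and from compound 1 cannot be read: the limit of > 50000 nM in this assay, at which 3 of the 3 values shown sit.

The compounds shown leave open whether piperidin-1-yl in place of pyrrolidin-1-yl, or isopropyl in place of methyl, changes inhibition at all, since none of them gives a measurable number.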